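The compounds below may be only part of what the source reports. "The series", "measured", "known", "first", "only" and "open" are said of these compounds alone.

Working notes on the series. The first point is compound 1 `C/C(=N\OCCCC(=O)O)c1ccc(Cl)cc1`; in a functional assay on the whole organism for inhibition, with Rattus norvegicus as the target, read by paw edema, with stated times of 1 h and 3 h (a higher number here means that more compound is needed for the effect, a lower number that less compound is needed), compound 1 gives 58 mg/kg. The second is compound 2 `CCOC(=O)CO/N=C(\C)c1ccc(Cl)cc1`; in this assay compound 2 gives 32 mg/kg. Within the data shown here, the single measured step, a 1.8-fold lower number from compound 1 to compound 2 (0.26 log units; within the scatter), changes the group on the saturated chain carbon bound to an oxygen. Among the measured compounds shown here, on the numbers so far compound 2 holds the lowest of the two, with compound 1 nearest, but that gap lies inside the scatter, so no order between the two can be read from it.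

The next point is compound 3 `C/C(=N\OCC(=O)OCCCCCCN(C)C)c1ccc(Cl)cc1`. Its change from compound 2 is 4-(dimethylamino)butyl in place of hydrogen on a saturated chain carbon, two bonds along the chain from an oxygen next to a carbonyl group. For the measured compounds named here, the one measured step that bears on this, a 1.8-fold lower number from compound 1 to compound 2 (0.26 log units; within the scatter), also altered the chain at the ester end and stayed inside the scatter, so there is no measured ground for expecting a step beyond the scatter in this assay in either direction. Compound 3 is therefore expected to give about 30 mg/kg in this assay, within 15 mg/kg to 65 mg/kg, which corresponds to an expected step of a 1.1-fold lower number from compound 2 to compound 3 (0.03 log units; within the scatter).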

Compound 3, dose for half-maximal effect: 66 mg/kg
Compound 3: middle estimate off by 2.2-fold (0.34 log units), on the low side; the measured number lies above the stated range.
By their numbers in this assay, from the lowest: compounds 2, 1 and 3 (each within the scatter of the next, the first and the last beyond it).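

In this assay, among these compounds, the position shows a response for the first time: a 2.1-fold higher number from compound 2 to compound 3 (0.31 log units; beyond the scatter), a modest step but the first beyond the scatter, with 4-(dimethylamino)butyl in place of hydrogen on a saturated chain carbon, two bonds along the chain from an oxygen next to a carbonyl group. The direction is toward more compound being needed for the effect, so this open-chain addition of 7 heavy atoms (6 carbon, 1 nitrogen) does not lower the number at this place, and the earlier step, which stayed within the scatter, gave no sign of this. Nothing available on the compounds bears on why the number moves, so the step stands here as an observation only.

The compounds shown leave open whether the step belongs to the length of the chain or to its terminal dimethylamino group, as this single change alters both at once. A plain hexyl ester would address the chain without the amine, and a 2-(dimethylamino)ethyl ester would address the amine on a shorter chain.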